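Changing the Aryl Group on the Amide Nitrogen

The source may hold more compounds than are shown below. What is called first, only, known or untested is meant among the compounds shown, and "the series" means these compounds.

Three compounds of one series have been measured in a functional assay on HEK293 cells for agonist activity at D(4) dopamine receptor (Homo sapiens), read by FLIPR; a lower number here means a smaller maximal response, a higher number a larger maximal response:

Compound 1 `Cc1cc(C)cc(NC(=O)CN2CCC(c3cccc[n+]3[O-])CC2)c1` gives 76%
Compound 2 `Cc1cc(Br)ccc1NC(=O)CN1CCC(c2cccc[n+]2[O-])CC1` gives 61%
Compound 3 `Cc1cc(F)ccc1NC(=O)CN1CCC(c2cccc[n+]2[O-])CC1` gives 84%

Compound 3 stands highest of the three numbers in this assay. Its nearest neighbour is compound 1, lying within the scatter: a number 8 percentage points higher from compound 1 to compound 3 (within the scatter). Its furthest is compound 2: a number 23 percentage points higher from compound 2 to compound 3 (beyond the scatter). Between compound 1 and compound 2 the step is a number 15 percentage points lower from compound 1 to compound 2 (beyond the scatter).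

Compound 4 `CSc1cccc(NC(=O)CN2CCC(c3cccc[n+]3[O-])CC2)c1` has not yet been measured. It differs from compound 3 in the group on the amide-type nitrogen: 3-(methylsulfanyl)phenyl in place of 4-fluoro-2-methylphenyl on an amide-type nitrogen.

Going by the values given here, none of the measured steps swaps the whole aryl group for one without a methyl; the two steps from compound 3 only change a halogen or move methyls on the ring, and both were modest or within the scatter. Since all three measured aryl groups keep the response within a fairly narrow band, compound 4 is expected to stay in that band as well, with the estimated step of a number 12 percentage points lower from compound 3 to compound 4 (beyond the scatter) being a small drop that may not exceed the scatter. The estimate for compound 4 in this assay is 72%, expected to lie between 52% and 90%.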

Compound 4, largest response reached (reported as efficacy), in percent of the reference or control that the assay uses: 56%
Estimate against measurement, compound 4: 16 percentage points above, within the range that was stated.
By their numbers in this assay, from the lowest: compounds 4 and 2 (each within the scatter of the next); then compounds 1 and 3 (each within the scatter of the next).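

In this assay, the 3-(methylsulfanyl)phenyl group on the amide-type nitrogen gives a number 28 percentage points lower from compound 3 to compound 4 (beyond the scatter) and also a number 20 percentage points lower from compound 1 to compound 4 (beyond the scatter) in a clear drop, so replacing either aryl group with this sulfur-bearing ring, which has no fluorine or ring methyl, does not keep the response at the level of those two compounds. Against the bromine-bearing ring, the same replacement gives a number 5 percentage points lower from compound 2 to compound 4 (within the scatter) and no real difference, which shows that two quite different aryl groups can share the low end of this small set, with both clearly under compound 1 and compound 3. Nothing available on these compounds bears on what lies behind these steps.

On these data alone, it remains open whether the sulfur atom itself matters, and a 3-methoxyphenyl group, with oxygen in place of sulfur, or a plain 3-methylphenyl group would help to separate the sulfur from the rest of the group. Also open, as far as these compounds go, is how the response would change with an aryl group carrying an amine or a carboxylic acid at this nitrogen.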